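A fluorine added where the anilide series sits at the limit

This account rests on a few compounds, and the source may have more. Where it says the series, first, only, none or still open, it means among the compounds named here.

Measured so far:
compound 1, `CCCCNc1cccc(NC(=O)c2ccc(OCCC)cc2)n1`: in an in vitro assay on HEK-tsA201 cells for antagonist activity at Neuronal acetylcholine receptor; alpha4/beta2 (Homo sapiens), read by fluorescence and calcium flux (a lower number here means a stronger inhibitor, a higher number a weaker inhibitor), compound 1 gives 54100 nM.
compound 2, `CCCCCNc1cccc(NC(=O)c2ccc(OCCC)cc2)n1`: compound 2 gives only an assay limit, > 100000 nM.
compound 3, `CCCOc1ccc(C(=O)Nc2cccc(Nc3ccccc3)n2)cc1`: compound 3 likewise gives only an assay limit, > 100000 nM.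

Compound 3 thus stands at the limit of > 100000 nM in this assay, at which 2 of the 3 values shown sit, alongside compound 2, while compound 1 alone returns a number. The steps leading into compound 3, an at least 1.8-fold higher number from compound 1 to compound 3 (0.26 log units; that floor lies within the scatter) and a step that the two limits leave unreadable from compound 2 to compound 3, exchange the alkyl group on the ring nitrogen and leave the phenyl ring untouched. Compound 4, `CCCOc1ccc(C(=O)Nc2cccc(Nc3ccc(F)cc3)n2)cc1`, differs from compound 3 by fluoro in place of hydrogen on an aromatic carbon. Among the compounds with values here, no measured step alters this ring, so the step that the limit leaves unreadable from compound 3 to compound 4 is expected to be none beyond the scatter. Compound 4 is therefore estimated at 150000 nM, with a range from 50000 nM to 500000 nM, most likely again only a limit in this assay.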

Compound 4, half-maximal inhibitory concentration: > 100000 nM
Compound 4 gave a limit, no number; the forecaster's own chance of this, stated with the estimate: 80%; the middle value does not contradict the limit.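

In this assay compound 4 gives > 100000 nM as a limit of the assay and not a number. Within the data shown here, the one readable step is an at least 1.8-fold higher number from compound 1 to compound 4 (0.26 log units; that floor lies within the scatter) and says no more than its floor; the steps into compound 4 from compound 3 and compound 2 cannot be read. The change from anilino to (4-fluorophenyl)amino thus leaves this position at the limit where anilino already stood: the limit of > 100000 nM in this assay, at which 3 of the 4 values shown sit.

Going by these compounds, whether chloro or methoxy in place of this fluoro would give a number stays open. So does the effect of a chain shorter than butyl on the same nitrogen.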